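The source may report more compounds than this note shows. Statements on the series, on what has been measured and on what is new or still open speak of the compounds shown alone.

Compound 1 `Cc1ccc(C(=O)c2ccn(-c3ccc4c(c3)B(O)OC4)c2)cc1` — in an ADME assay on L929 cells (Mus musculus) for cytotoxicity, read by resazurin assay, with a stated time of 72 h (a higher number here means a weaker inhibitor, a lower number a stronger inhibitor), compound 1 gives > 10 ug/mL, which is a limit of the assay rather than a number.
Compound 2 `COc1ccc(C(=O)c2ccn(-c3ccc4c(c3)B(O)OC4)c2)cc1` — in this assay compound 2 gives > 10 ug/mL, again a limit rather than a number.
Compound 3 `O=C(c1ccc(O)cc1)c1ccn(-c2ccc3c(c2)B(O)OC3)c1` — in this assay compound 3 gives > 10 ug/mL, also a limit rather than a number.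

Compound 3 therefore stands at the same limit as the other two compounds, and nothing separates them: the limit of > 10 ug/mL in this assay, at which 3 of the 3 values shown sit. The three measured steps, a step that the two limits leave unreadable from compound 1 to compound 2, a step that the two limits leave unreadable from compound 1 to compound 3 and a step that the two limits leave unreadable from compound 2 to compound 3, cannot be read in size or direction, since each runs between two limits.

Compound 4 `CCCC(=O)c1ccn(-c2ccc3c(c2)B(O)OC3)c1` differs from compound 3 by propyl in place of 4-hydroxyphenyl on a carbonyl carbon. For the measured compounds named here, none of the measured steps touches the group on the carbonyl carbon; they vary only the substituent on the aryl ring, and all leave the value at the limit. The measured steps thus give no readable direction for the change to compound 4, and the expectation rests only on the shared core sitting at the limit throughout.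

Compound 4 is expected to remain near that limit, with the estimated step that the limit leaves unreadable from compound 3 to compound 4 not resolvable beyond the scatter. For compound 4 the estimate in this assay is 15 ug/mL, with a range from 5 ug/mL to 40 ug/mL.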

Compound 4, half-maximal inhibitory concentration: > 10 ug/mL
Compound 4: a limit, no number; the forecaster's own chance of this, stated with the estimate: 65%; the middle value does not contradict the limit.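

In this assay compound 4 gives > 10 ug/mL, again a limit rather than a number, so its steps from compound 1, compound 2 and compound 3 cannot be read: the limit of > 10 ug/mL in this assay, at which 4 of the 4 values shown sit.

The compounds shown leave open whether the group on the carbonyl carbon changes the value in this assay at all.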